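Aryl variation on the ring amine nitrogen; compound 3 expected

The source may hold more compounds than are shown below. What is called first, only, known or untested is meant among the compounds shown, and "the series" means these compounds.

Within the data shown here, compound 2 `Nc1scc(CN2CCN(c3cccc(C(F)(F)F)c3)CC2)c1C(=O)c1ccc(Cl)cc1` stands lowest of the two numbers so far: in an assay on CHO cells for displacement of a labelled ligand from adenosine receptor A3 (Homo sapiens), read by scintillation counting, with a stated time of 120 min, tested at 10 uM (a higher number here means more inhibition at the concentration tested (going by the name of the read-out), a lower number less inhibition), compound 2 gives 0%. Its nearest neighbour is compound 1 `Nc1scc(CN2CCN(c3ccc([N+](=O)[O-])cc3)CC2)c1C(=O)c1ccc(Cl)cc1`, which in this assay gives 2%; the step of a number 2 percentage points lower from compound 1 to compound 2 (within the scatter) is within the scatter. Compound 3 `Nc1scc(CN2CCN(c3ccncc3)CC2)c1C(=O)c1ccc(Cl)cc1` differs from compound 2 by pyridin-4-yl in place of 3-(trifluoromethyl)phenyl on an amine nitrogen in a ring. Among the measured compounds shown here, the only measured step that bears on this, 3-(trifluoromethyl)phenyl in place of 4-nitrophenyl on the same amine nitrogen in a ring, stayed within the scatter, so no step beyond the scatter is expected in this assay, in either direction. For compound 3 the expected value in this assay is 2%, range -8% to 12%, an expected step of a number 2 percentage points higher from compound 2 to compound 3 (within the scatter).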

Compound 3, a percentage reported as inhibition, at one concentration (the size of the read-out at that concentration, not a potency): 2%
For compound 3 middle estimate and measured number coincide at the digits printed; low and high end bracket the measured number.
By their numbers in this assay, from the lowest: compounds 2, 1 and 3 (each within the scatter of the next).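

Pyridin-4-yl on the amine nitrogen in the ring gives a number 2 percentage points higher from compound 2 to compound 3 (within the scatter) and no change at the digits printed from compound 1 to compound 3 (within the scatter) in this assay. This position has now carried a six-membered aromatic ring with a hetero atom as well as two of carbon only, with no step beyond the scatter among the three compounds. Nothing at hand accounts for this flat result. Still open, as far as these compounds go, is whether a different kind of group on this nitrogen, such as benzyl or a longer alkyl chain, gives a step beyond the scatter. From the compounds shown here alone, whether a change on the shared core does so is also open.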